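The source may hold more compounds than are shown below. What is called first, only, known or untested is meant among the compounds shown, and "the series" means these compounds.

The study covers two measured compounds and one not yet measured, all built on the same core but carrying different long chains. Compound 1 `CCCCCCCCC(C)CC/C(O)=C1\C(=O)[C@H](C)N(C)C1=O` was tested in a functional assay on A498 cells (Homo sapiens) for inhibition; a higher number here means a weaker inhibitor, a lower number a stronger inhibitor. For compound 1 this assay records only a limit, < 10000 nM, and not a number. Compound 2 `CC(C)CCCCCCCCCCC/C(O)=C1\C(=O)C(C)N(C)C1=O` is the one compound with a real value: in this assay compound 2 gives 3400 nM, the only number shown. The only other entry, that of compound 1, is the limit of < 10000 nM in this assay, at which 1 of the 2 values shown sits. Compound 3 `CCC(C)CCCCCCCCCC/C(O)=C1\C(=O)C(C)N(C)C1=O` has not yet been measured. It differs from compound 2 in one place: sec-butyl in place of isobutyl on a saturated chain carbon, ten or more bonds along the chain from a double-bonded chain carbon. Among the compounds with values here, no step between measured compounds is available here, so nothing shows how a change at this place on the saturated chain has shifted the result before. The two chains hold the same atoms joined differently, so the step expected in this assay is none beyond the scatter, a 1.0-fold higher number from compound 2 to compound 3 (0.01 log units; within the scatter). Compound 3 is therefore expected to give 3500 nM in this assay, with a range from 1500 nM to 8000 nM.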

Compound 3, half-maximal inhibitory concentration: < 10000 nM
Compound 3 ended at the assay's limit; the forecaster's own chance of this, stated with the estimate: 15%; the middle value is on the limit's open side.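

In this assay compound 3 gives < 10000 nM, which is a limit of the assay and not a number. No new step can be read from compound 2 to compound 3, and the values shown offer little to compare: the limit of < 10000 nM in this assay, at which 2 of the 3 values shown sit.

The compounds shown leave open whether sec-butyl in place of isobutyl on this saturated chain carbon changes the result in this assay, and in which direction.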